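The compounds below may be only part of what the source reports. "The series", "measured", "known", "first", "only" and "open" are said of these compounds alone.

Compound 3 `CNC(=O)[C@@]12C[C@@H]1[C@@H](n1cnc3c(NC)nc(C#Cc4cccnn4)nc31)[C@H](O)[C@@H]2O` gives 3.53 nM in an assay on CHO cells for displacement of a labelled ligand from adenosine receptor A3 (Homo sapiens), read by scintillation counting, with a stated time of 60 min (a higher number here means a weaker inhibitor, a lower number a stronger inhibitor), the highest of the three numbers measured, though compound 1 `CNC(=O)[C@@]12C[C@@H]1[C@@H](n1cnc3c(NC)nc(C#Cc4ccc(CO)cc4)nc31)[C@H](O)[C@@H]2O` at 2.16 nM and compound 2 `CNC(=O)[C@@]12C[C@@H]1[C@@H](n1cnc3c(NC)nc(C#Cc4cccnc4)nc31)[C@H](O)[C@@H]2O` at 2.15 nM both lie within the scatter of it. Compound 4 `CNC(=O)[C@@]12C[C@@H]1[C@@H](n1cnc3c(NC)nc(C#Cc4cnn(C)c4)nc31)[C@H](O)[C@@H]2O` differs from compound 3 by 1-methyl-1H-pyrazol-4-yl in place of pyridazin-3-yl on a triple-bonded carbon. Going by the values given here, the steps that bear on this swap are all exchanges of the aromatic group on the triple-bonded carbon: a 1.0-fold lower number from compound 1 to compound 2 (0.00 log units; within the scatter), a 1.6-fold higher number from compound 1 to compound 3 (0.21 log units; within the scatter) and a 1.6-fold higher number from compound 2 to compound 3 (0.22 log units; within the scatter), none of them beyond the scatter. A further aromatic ring in the same place is therefore expected to shift the number in this assay by no more than the scatter, in either direction. Compound 4 is thus estimated at 3 nM, between 1.4 nM and 7 nM, a step of a 1.2-fold lower number from compound 3 to compound 4 (0.07 log units; within the scatter).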

Compound 4, inhibition constant: 2.34 nM
The estimate for compound 4 lay 1.3-fold (0.11 log units) above the measured number, and the stated range covers the measured number.
By their numbers in this assay, from the lowest: compounds 2, 1, 4 and 3 (each within the scatter of the next).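

Going by these compounds alone, compound 4 places a five-membered aromatic ring on the triple-bonded carbon, where the earlier compounds carry six-membered ones, and in this assay the steps stay small: a 1.5-fold lower number from compound 3 to compound 4 (0.18 log units; within the scatter) and a 1.1-fold higher number from compound 2 to compound 4 (0.04 log units; within the scatter) and a 1.1-fold higher number from compound 1 to compound 4 (0.03 log units; within the scatter). Among these four compounds, then, ring size at this position does not separate the numbers. No measurement here offers a reason for this.

On these data alone, all four groups are aromatic rings, so it remains open whether a primary amine, a carboxylic acid or a longer alkyl chain on the triple-bonded carbon would stay within the scatter.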